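Removing the bromo group from compound 1

A few compounds are considered here, and "the series" means these few. Any claim that something is new, unique, unknown or untested is made for them only; others in the source may bear on it.

Measured in a functional assay on MGC-803 cells (Homo sapiens) for inhibition, read by MTT assay, with a stated time of 48 h; a lower number here means a stronger inhibitor, a higher number a weaker inhibitor:
compound 1 `COc1ccc(CNc2cc(OC)c(OC)c(OC)c2)cc1Br` gives 29400 nM
compound 2 `C/C=C/C=C/C(=O)N(Cc1ccc(OC)c(O)c1)c1cc(OC)c(OC)c(OC)c1` gives 140 nM
compound 3 `C/C=C/C(=O)N(Cc1ccc(OC)c(Br)c1)c1cc(OC)c(OC)c(OC)c1` gives 6430 nM

Compound 1 has the highest number of the three and is the weakest inhibitor among them. Compound 2 lies furthest from it, and compound 3 lies nearest. The step to compound 4 `COc1ccc(CNc2cc(OC)c(OC)c(OC)c2)cc1` is a single change: hydrogen in place of bromo on an aromatic carbon with hydrogen in place of bromo on an aromatic carbon, ortho to a methoxy group. For the measured compounds named here, the one measured step of a 4.6-fold lower number from compound 1 to compound 3 (0.66 log units; beyond the scatter) is a change on the nitrogen and not at this aromatic carbon, so it offers only a sense of scale and no direction. Going by the values given here, no pair of measured compounds differs by the bromo group alone. On these data alone, no step beyond the scatter is therefore expected in this assay and the direction stays open. The expected step is a 1.0-fold higher number from compound 1 to compound 4 (0.01 log units; within the scatter) and it is small. For compound 4 the estimate is 30000 nM with an expected range of 10000 nM to 85000 nM for the measurement.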

Compound 4, half-maximal inhibitory concentration: 11400 nM
Beside the measured number, compound 4's estimate is 2.6-fold (0.42 log units) above it; the measured number falls inside the stated range.
By their numbers in this assay, from the lowest: compound 2; then compounds 3 and 4 (each within the scatter of the next); then compound 1.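

In this assay, for the compounds shown here, this is the first reading of the bromo group ortho to a methoxy group as a single change: hydrogen in its place gives a 2.6-fold lower number from compound 1 to compound 4 (0.41 log units; beyond the scatter). With the hydrogen kept on the nitrogen, the bromo group is therefore not needed for inhibition on the core of compound 1, and its removal lowers the number rather than leaving it unchanged. No measurement available here accounts for this step.

On these data alone, whether hydrogen in place of bromo moves the number the same way when the nitrogen carries the (prop-1-en-1-yl)carbonyl group of compound 3 stays open. As far as these compounds go, how a chloro group or an amine on this aromatic carbon would compare with bromo and hydrogen also stays open.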